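Branch methylation of the ketone side chain and microsomal stability

The source may report more compounds than this note shows. Statements on the series, on what has been measured and on what is new or still open speak of the compounds shown alone.

Measured so far:
compound 1 `COc1cc(C(=O)O)ccc1OCCCCOc1ccc(C(=O)CC(C)C)c(O)c1C` gives 43% in an ADME assay (liver) for metabolic stability, with Liver microsome (Rattus norvegicus) as the target, read by LC-MS, using microsomes and NADPH, with stated times of 5 min and 60 min, tested at 4 uM; on this read-out lower numbers stand for a less stable compound and higher numbers for a more stable compound;
compound 2 `CCCC(=O)c1ccc(OCCCCOc2cc(C(=O)O)ccc2OC)c(C)c1O` gives 1% in this assay;
compound 3 `COc1ccc(C(=O)O)cc1OCCCCOc1ccc(C(=O)CC(C)C)c(O)c1C` gives 5% in this assay.

Compound 4 `COc1cc(C(=O)O)ccc1OCCCCOc1ccc(C(=O)CC(C)(C)C)c(O)c1C` has not yet been measured. It differs from compound 1 by methyl in place of hydrogen on a saturated chain carbon bound to three saturated chain carbons. The same kind of change separates compound 3 from compound 2, namely (methyl in place of hydrogen on a saturated chain carbon bound to two saturated chain carbons); the two places are not identical, since in one case the carbon is bound to three saturated chain carbons and in the other to two. How the core of compound 1 differs from that of compound 2 is not broken down here. The measured step of a number 4 percentage points higher from compound 2 to compound 3 (within the scatter) was small. On that basis the step of a number 5 percentage points higher from compound 1 to compound 4 (within the scatter) is expected to be small as well. Compound 4 is therefore estimated to reach 48%, between 25% and 70%.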

Compound 4, percent of the compound remaining: 49%
For compound 4 the middle estimate is 1 percentage points below the measured one; measured number inside the range.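

In this assay the methyl that turns isobutyl into neopentyl gave a number 6 percentage points higher from compound 1 to compound 4 (within the scatter), a small step that matches the one seen on the other core: the same change on two cores in this assay, a number 4 percentage points higher (within the scatter) from compound 2 to compound 3 and a number 6 percentage points higher (within the scatter) from compound 1 to compound 4, 2 percentage points apart, within the scatter of two such steps
On these two cores, the change therefore carries over as a step too small to tell from the scatter, although the carbon receiving the methyl is bound to three saturated chain carbons in one case and two in the other. This does not show that the methyl changes stability at all, and two pairs cannot establish how it would behave on any further core.

From the compounds shown here alone, it remains open what an amine or a longer chain in place of the neopentyl group would do in this assay. Going by these compounds, a cyclopropyl ring at that place is equally open.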